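Adding methoxymethyl to compound 3

A few compounds are considered here, and "the series" means these few. Any claim that something is new, unique, unknown or untested is made for them only; others in the source may bear on it.

Values in a physicochemical assay for solubility, in phosphate buffer, measured as kinetic solubility; a lower number here means a less soluble compound, a higher number a more soluble compound:
compound 1 `COCc1cc(OC)c(-c2cccc3c(N(CC4CCOCC4)CC4CC4)c(C)nn23)c(OC)c1`: 21000 nM
compound 2 `COCc1cc(OC)c(-c2cccc3c(N(CC4CCOCC4)CC4CC4)c(C#N)nn23)c(OC)c1`: 1700 nM
compound 3 `CCc1nn2c(-c3c(OC)cccc3OC)cccc2c1N(CC1CCOCC1)CC1CC1`: 3300 nM

In this assay compound 3 gives 3300 nM, a value that cannot be separated from compound 2 at 1700 nM. Compound 1 gives 21000 nM, and its gaps to these two lie beyond the scatter.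

Compound 4 `CCc1nn2c(-c3c(OC)cc(COC)cc3OC)cccc2c1N(CC1CCOCC1)CC1CC1` carries methoxymethyl in place of hydrogen on an aromatic carbon of compound 3: methoxymethyl in place of hydrogen on an aromatic carbon.

For the measured compounds named here, no measured step isolates this change. Going by the values given here, the only one available, a 12-fold lower number from compound 1 to compound 2 (1.09 log units; beyond the scatter), is large, but it exchanges a different group at a different place, so it shows only that a single change can move this series well beyond the scatter. Compound 4 shares the methoxymethyl group with compound 1 at 21000 nM, which points to a rise. Compound 2 goes against that reading, since it carries the same group and gives 1700 nM. A moderate rise in this assay is therefore expected, with no change beyond the scatter also remaining possible.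

The estimated step is a 2.4-fold higher number from compound 3 to compound 4 (0.38 log units; beyond the scatter).

Compound 4 is expected at 8000 nM, with an estimated range of 2500 nM to 22000 nM.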

Compound 4, solubility: 4800 nM
Compound 4: the middle estimate sits 1.7-fold (0.22 log units) above what was measured, and the stated range covers the measured number.
By their numbers in this assay, from the lowest: compounds 2, 3 and 4 (each within the scatter of the next, the first and the last beyond it); then compound 1.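

In this assay, methoxymethyl in place of hydrogen on this aromatic carbon, para to a large group and meta to two methoxy groups, gives a 1.5-fold higher number from compound 3 to compound 4 (0.16 log units; within the scatter), so this single change is not resolved from the scatter on the ethyl background. The larger movement among the compounds carrying methoxymethyl comes from the other place: a 4.4-fold lower number from compound 1 to compound 4 (0.64 log units; beyond the scatter) for methyl in place of hydrogen on a saturated chain carbon bound to an aromatic carbon, and a 2.8-fold higher number from compound 2 to compound 4 (0.45 log units; beyond the scatter) for ethyl in place of cyano on an aromatic carbon. With methoxymethyl held fixed, the numbers therefore run from nitrile through ethyl to methyl, with each gap beyond the scatter, and the value of compound 1 does not carry over to compound 4 through the shared group. No measurement at hand bears on the reason for the size of these steps.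

Whether methoxymethyl stays equally unresolved with methyl or nitrile in place of ethyl remains open, since compound 3 is the only compound shown without it. Also open, as far as these compounds go, is whether an amine or a carboxylic acid on this aromatic carbon would move the number beyond the scatter.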